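This account rests on a few compounds, and the source may have more. Where it says the series, first, only, none or still open, it means among the compounds named here.

Compound 1 `CCCC[C@H](NC(=O)[C@H](CCCCN)NC(=O)[C@H](CCCNC(=N)N)NC(=O)c1ccccc1)C(N)=O` is the parent of the small series, and in an ADME assay for permeability, using PAMPA (on this read-out higher numbers stand for higher permeability and lower numbers for lower permeability), compound 1 is reported only as "impermeable" (no number reported), without a number. Two analogues carry a larger group on the benzamide ring of that core. Compound 2 `CCCC[C@H](NC(=O)[C@H](CCCCN)NC(=O)[C@H](CCCNC(=N)N)NC(=O)c1ccc(/C=C2\SC(=O)N(c3ccc(C)cc3)C2=O)cc1)C(N)=O` gives 0.66 10^-6 cm/s in this assay. Compound 3 `CCCC[C@H](NC(=O)[C@H](CCCCN)NC(=O)[C@H](CCCNC(=N)N)NC(=O)c1ccc(/C=C2\SC(=S)N(C3CCCC3)C2=O)cc1)C(N)=O` gives 2.31 10^-6 cm/s in this assay. Of the two numbers on record, compound 2 has the lower one, and the gap from compound 2 up to compound 3 lies beyond the usual scatter of repeated measurements.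

The next compound, compound 4 `CCCC[C@H](NC(=O)[C@H](CCCCN)NC(=O)[C@H](CCCNC(=N)N)NC(=O)c1ccc(/C=C2\SC(=O)N(Cc3ccc(F)cc3)C2=O)cc1)C(N)=O`, is not yet measured. Compared with compound 2, its change is 4-fluorobenzyl in place of 4-methylphenyl on an amide-type nitrogen in a ring. Among the measured compounds shown here, no pair of measured compounds shows this kind of exchange, so there is no step on record to lean on; the only guidance is that compound 2 and compound 3, which differ at several places at once, both give numbers in the low range. The step from compound 2 to compound 4 is expected to be a 1.4-fold higher number from compound 2 to compound 4 (0.13 log units; within the scatter), most likely within the scatter, with the direction uncertain. Compound 4 is estimated at 0.9 10^-6 cm/s in this assay, between 0.35 10^-6 cm/s and 2.3 10^-6 cm/s.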

Compound 4, apparent permeability: 0.43 10^-6 cm/s
Beside the measured number, compound 4's estimate is 2.1-fold (0.32 log units) above it; the measured number falls inside the stated range.
By their numbers in this assay, from the lowest: compounds 4 and 2 (each within the scatter of the next); then compound 3.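

In this assay, among the compounds shown here, 4-fluorobenzyl in place of 4-methylphenyl on the amide-type nitrogen in the ring gives a 1.5-fold lower number from compound 2 to compound 4 (0.19 log units; within the scatter), and this is the only step on record that changes one place alone. The earlier compounds shown here differed at several places at once, so they could not show what this position does by itself. Here, one group holding a six-membered aromatic ring of carbon only and no net charge gives way to another of the same description, and the number stays within the scatter, so at this position and for this exchange the assay separates the two compounds no more than repeated measurement would. No measurement on record gives a reason for this result.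

The compounds shown leave open whether a group of another kind on this nitrogen, such as an amine, a carboxylic acid or a longer chain, would carry the number beyond the scatter. They also leave open whether the same exchange would read alike when made on compound 3, which carries a cyclopentyl group at this place.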